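Removing a Chlorine from a Weak Oxadiazole Inhibitor

The source may report more compounds than this note shows. Statements on the series, on what has been measured and on what is new or still open speak of the compounds shown alone.

Measured compounds:
- Compound 1, `COc1cc(-c2nnc(C3CCc4cc(F)ccc4O3)o2)cc(OC)c1OC`: 43200 nM
- Compound 2, `Fc1ccc2c(c1)CCC(c1nnc(-c3cccc(Cl)c3)o1)O2`: 23100 nM
- Compound 3, `O=c1cc(-c2nnc(C3CCc4cc(F)ccc4O3)o2)oc2ccc(F)cc12`: 34900 nM

All three compounds were tested in a functional assay; on this read-out lower numbers stand for stronger inhibition and higher numbers for weaker inhibition. Compound 2 shows the lowest number of the three, but its gap to compound 3 and its gap to compound 1 both lie within the usual scatter of repeated measurements, so the three values cannot be ranked against each other with any confidence. All three are weak inhibitors on this read-out.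

The next compound, compound 4, `Fc1ccc2c(c1)CCC(c1nnc(-c3ccccc3)o1)O2`, differs from compound 2 in one place: hydrogen in place of chloro on an aromatic carbon. Seen one bond further out, the change reads 3-chlorophenyl to phenyl.

Among the compounds with values here, no pair of measured compounds differing in a single place is available here, so there is no measured step to lean on. Based only on compound 2 and its value in this assay, the expected outcome is a modest move toward a higher number, a 1.7-fold higher number from compound 2 to compound 4 (0.24 log units; within the scatter), with a real chance that the change stays within the scatter. Compound 4 is therefore estimated at 40000 nM in this assay, within a range from 15000 nM to 110000 nM.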

Compound 4, half-maximal inhibitory concentration: 28700 nM
The estimate for compound 4 lay 1.4-fold (0.14 log units) above the measured number; measured number inside the range.
By their numbers in this assay, from the lowest: compounds 2, 4, 3 and 1 (each within the scatter of the next).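

Within the data shown here, on this assay the swap of chloro for hydrogen on this aromatic carbon gives a 1.2-fold higher number from compound 2 to compound 4 (0.09 log units; within the scatter), the first step here between two compounds that differ in only one place. The 3-chlorophenyl and phenyl versions therefore cannot be told apart on this read-out, and the chlorine is not needed for the weak inhibition seen with compound 2. No supporting measurement is available to explain this result.

From the compounds shown here alone, whether any group at this place can move the number beyond the scatter remains open, for example an amine or a carboxylic acid on the same aromatic carbon. Going by these compounds, it is also open whether the same swap would behave alike on the cores of other compounds, since this single step comes from one pair.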